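Sulfonamide swap in a series sitting at the assay limit

The compounds below may be only part of what the source reports. "The series", "measured", "known", "first", "only" and "open" are said of these compounds alone.

The shared core of compound 2 `O=S(=O)(Nc1ccc2oc(-c3ccccc3)nc2c1)c1ccccc1Cl` carries a 2-chlorophenyl group on the sulfonyl sulfur, and in an assay on isolated protein for inhibition of malate dehydrogenase, mitochondrial (Sus scrofa), with stated times of 45 min and 30 min (on this read-out lower numbers stand for stronger inhibition and higher numbers for weaker inhibition), compound 2 gives > 63000 nM, which is a limit of the assay and not a number. Compound 1 `O=S(=O)(Nc1ccc2oc(-c3ccccc3)nc2c1)c1ccccc1C(F)(F)F` gives in this assay > 63000 nM, likewise a limit. Compound 3 `O=S(=O)(Nc1ccc(-c2nc3ccccc3o2)cc1)c1ccc(C(F)(F)F)cc1`, with the sulfonamide on a different position of the core, gives in this assay > 63000 nM, again a limit. For the measured compounds named here, the one step among measured compounds, a step that the two limits leave unreadable from compound 1 to compound 2, is therefore of no readable size, and the limit of > 63000 nM in this assay, at which 3 of the 3 values shown sit, shows where all three values sit.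

Compound 4 `C=Cc1ccc(S(=O)(=O)Nc2ccc3oc(-c4ccccc4)nc3c2)cc1` differs from compound 2 by 4-vinylphenyl in place of 2-chlorophenyl on a sulfonyl sulfur. Going by the values given here, no measured step bears on this change, and every compound in view rests on the limit, so the expectation for compound 4 in this assay is that it too will most likely remain at or beyond that limit, with a step that the limit leaves unreadable from compound 2 to compound 4 that is expected to be unreadable. The estimate for compound 4 is 90000 nM, between 30000 nM and 300000 nM.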

Compound 4, half-maximal inhibitory concentration: > 63000 nM
Compound 4 gave a limit, no number (the forecaster's own chance of this, stated with the estimate: 85%); the middle value does not contradict the limit.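

Compound 2 and compound 4 each give only a limit of the assay and not a number, so no size can be read for the step between them. The compounds shown leave open which structural change, if any, would give a readable value in this assay.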